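The source may hold more compounds than are shown below. What is called first, only, known or untested is meant among the compounds shown, and "the series" means these compounds.

Working notes on the series.

Compound 1 `CC(C)CCOc1cc(C(C)(C)C)ccc1CNC(=O)C(C)c1ccc(NS(C)(=O)=O)c(F)c1` and compound 2 `CC(C(=O)NCc1ccc(C(C)(C)C)cc1SC1CCCCC1)c1ccc(NS(C)(=O)=O)c(F)c1` share one core and differ only at one aromatic carbon. In an assay on cells for antagonist activity at transient receptor potential cation channel subfamily V member 1 (Homo sapiens), read by FLIPR and calcium flux, with a stated time of 6 min (a lower number here means a stronger inhibitor, a higher number a weaker inhibitor), compound 1 gives 0.6 nM, while compound 2 gives 7.4 nM. Within the data shown here, the one step measured so far, a 12-fold higher number from compound 1 to compound 2 (1.09 log units; beyond the scatter), shows that the group at this position moves the number strongly; on the two numbers known, compound 2 stands as the higher of the pair, the nearer (and only) neighbour being compound 1.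

Compound 3 `CC(C(=O)NCc1ccc(C(C)(C)C)cc1C1CCCCC1)c1ccc(NS(C)(=O)=O)c(F)c1` is not yet measured. Its change from compound 2 is cyclohexyl in place of cyclohexylsulfanyl on an aromatic carbon. Among the measured compounds shown here, no measured step bears directly on this change: the only step known swaps one whole substituent for another, and none removes a sulfur link while keeping the ring. That step is large, so this position is sensitive, but it gives no direction for the present change. The expectation for this assay is therefore a step of modest size either way, a 1.4-fold higher number from compound 2 to compound 3 (0.13 log units; within the scatter), without a firm sign. Compound 3 is estimated at 10 nM, with a range from 3 nM to 40 nM.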

Compound 3, inhibition constant: 9.8 nM
Compound 3: middle estimate off by 1.0-fold (0.01 log units), on the high side; measured number inside the range.
By their numbers in this assay, from the lowest: compound 1; then compounds 2 and 3 (each within the scatter of the next).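

In this assay, cyclohexyl in place of cyclohexylsulfanyl on this aromatic carbon gives a 1.3-fold higher number from compound 2 to compound 3 (0.12 log units; within the scatter), so with the six-membered carbon ring kept, the sulfur link can be lost with no difference these numbers can resolve. The comparison with the isopentyloxy compound, a 16-fold higher number from compound 1 to compound 3 (1.21 log units; beyond the scatter), is large and matches the earlier 12-fold higher number from compound 1 to compound 2 (1.09 log units; beyond the scatter); compound 1 thus stands apart from both ring-bearing compounds, and the sensitivity of this position shows in the exchange of isopentyloxy for either ring group, not in the exchange of one ring group for the other. No measurement on hand explains the separation between isopentyloxy and the two ring groups.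

The compounds shown leave open whether the ring or the chain is what matters, since isopentyloxy differs from both ring groups in its linking atom as well as in its carbon skeleton. A cyclohexyloxy group, which would join the ring through oxygen, and an isopentyl chain joined directly through carbon would separate these two features.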